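Phenyl in Place of Cyclohexyl: Expecting Compound 4

The source may hold more compounds than are shown below. What is called first, only, known or untested is meant among the compounds shown, and "the series" means these compounds.

Compound 1, `C(=C/c1nn2c(-c3ccncc3)nnc2s1)\c1ccco1`, gives 82% in an assay for inhibition of histone-lysine N-methyltransferase, H3 lysine-79 specific (Homo sapiens), read by scintillation counting, with stated times of 15 min and 60 min, tested at 100 uM, in the presence of a further agent that is not named here; on this read-out higher numbers stand for a stronger effect at the one concentration tested and lower numbers for a weaker effect.
Compound 2, `Cc1cccc(-c2nnc3sc(/C=C/c4ccco4)nn23)c1`, gives 74% in this assay.
Compound 3, `C(=C/c1nn2c(C3CCCCC3)nnc2s1)\c1ccco1`, gives 72% in this assay.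

All three numbers lie within the usual scatter of one another. Compound 3 carries the smallest of them as written, with a number 2 percentage points lower from compound 2 to compound 3 (within the scatter) and a number 10 percentage points lower from compound 1 to compound 3 (within the scatter), neither step being large enough to count as a real difference.

Compound 4, `C(=C/c1nn2c(-c3ccccc3)nnc2s1)\c1ccco1`, is not yet measured. It differs from compound 3 in one place: phenyl in place of cyclohexyl on an aromatic carbon.

Among the compounds with values here, two measured steps bear on this position. The 3-methylphenyl of compound 2 against the cyclohexyl of compound 3 gave a number 2 percentage points lower from compound 2 to compound 3 (within the scatter), and the pyridin-4-yl of compound 1 against the cyclohexyl of compound 3 gave a number 10 percentage points lower from compound 1 to compound 3 (within the scatter). Both exchanges at this carbon left the read-out within the scatter, so no step beyond the scatter is expected when phenyl replaces cyclohexyl. Compound 4 is therefore estimated at 75%, between 62% and 88%, which is an expected a number 3 percentage points higher from compound 3 to compound 4 (within the scatter).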

Compound 4, a percentage reported as inhibition, at one concentration (the size of the read-out at that concentration, not a potency): 81%
For compound 4 the middle estimate is 6 percentage points below the measured one; the range from low to high includes it.
By their numbers in this assay, from the lowest: compounds 3, 2, 4 and 1 (each within the scatter of the next).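

With the plain phenyl of compound 4, this aromatic carbon now carries four different six-membered rings, and an aromatic ring of carbon only in place of the non-aromatic cyclohexyl gives a number 9 percentage points higher from compound 3 to compound 4 (within the scatter) in this assay. Hydrogen in place of the methyl on that phenyl gives a number 7 percentage points higher from compound 2 to compound 4 (within the scatter), and phenyl in place of pyridin-4-yl gives a number 1 percentage points lower from compound 1 to compound 4 (within the scatter), so neither the methyl of compound 2 nor the ring nitrogen of compound 1 moves the read-out beyond the scatter. Nothing available here accounts for this insensitivity at the position.

All the groups shown at this carbon are six-membered rings, so the effect of an amine, a carboxylic acid or a longer alkyl chain there remains open. Each compound is also read at one concentration only, so the numbers speak only of a stronger or weaker effect at that concentration, and how the four would compare at any other concentration remains unresolved.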